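The compounds below may be only part of what the source reports. "The series", "measured", "known", "first", "only" and "open" are said of these compounds alone.

Measured compounds:
compound 1, `Cn1cc(SCc2nnc(SCc3ccccc3C#N)n2-c2c(Cl)cccc2Cl)c2ccccc21`, giving 78600 nM in a toxicity assay on HEK-293T cells (Homo sapiens) for cytotoxicity, read by CCK-8 assay, with a stated time of 48 h; on this read-out higher numbers stand for lower toxicity in this test and lower numbers for higher toxicity in this test
compound 2, `Cn1cc(SCc2nnc(SCc3c(Cl)cccc3Cl)n2-c2c(Cl)cccc2Cl)c2ccccc21`, giving > 100000 nM in this assay

For compound 2 the result in this assay is a limit of the assay, not a number: compound 2 gives > 100000 nM, which is the limit of > 100000 nM in this assay, at which 1 of the 2 values shown sits. Compound 3, `Cn1cc(SCc2nnc(SCc3cc(Cl)ccc3F)n2-c2c(Cl)cccc2Cl)c2ccccc21`, is not yet measured. It differs from compound 2 in one place: 5-chloro-2-fluorophenyl in place of 2,6-dichlorophenyl on a saturated chain carbon bound to a sulfur. Among the compounds with values here, the only measured step at that same place is an at least 1.2-fold higher number from compound 1 to compound 2 (0.10 log units; that floor lies within the scatter), in which a 2-cyanophenyl became a 2,6-dichlorophenyl. That step stayed within the usual scatter and ended at the limit, so it offers little guidance on the size of the next change. Exchanging one substituted phenyl group for another at this place is therefore expected to move the number by no more than the scatter, in no particular direction, so the expected step is a number no higher from compound 2 to compound 3 (the limit leaves the size open). Compound 3 is estimated at 100000 nM, between 50000 nM and 200000 nM, with a fair chance that the assay again reports only its limit.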

Compound 3, half-maximal cytotoxic concentration: > 100000 nM
Compound 3 ended at the assay's limit; the forecaster's own chance of this, stated with the estimate: 50%; the middle value lies on the limit itself.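

Exchanging the 2,6-dichlorophenyl for a 5-chloro-2-fluorophenyl on a saturated chain carbon bound to a sulfur does not bring the result back inside the measurable range, so the limit is no longer tied to a single substituted phenyl group: the limit of > 100000 nM in this assay, at which 2 of the 3 values shown sit.

With both compound 2 and compound 3 at that limit, the step between them cannot be read, and nothing can be said about how these two compare. Starting from the 2-cyanophenyl, this assay shows an at least 1.2-fold higher number from compound 1 to compound 3 (0.10 log units; that floor lies within the scatter), a floor too small to separate the two compounds.

Going by these compounds, all three compounds carry a substituted phenyl at this place, so it stays open how far the true values of compound 2 and compound 3 lie past the limit. On these data alone, it also stays open whether an amine, a carboxylic acid or a longer chain in place of the benzyl group would give a clearly lower number.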